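Adding a Second Chloro to the Purine of Compound 1

This account rests on a few compounds, and the source may have more. Where it says the series, first, only, none or still open, it means among the compounds named here.

Compound 1 `ClCc1cccc(Cn2cnc3ncnc(Cl)c32)c1` was tested in a functional assay on IGROV-1 cells (Homo sapiens) for cytotoxicity, read by sulforhodamine B assay, with a stated time of 48 h (on this read-out higher numbers stand for weaker inhibition of growth and lower numbers for stronger inhibition of growth), where it gives 3380 nM. That is the highest of the two numbers recorded so far. Compound 2 `ClCc1ccc(Cn2cnc3nc(Cl)nc(Cl)c32)cc1` differs from compound 1 in several places. In this assay compound 2 gives 1410 nM, a lower number that lies beyond the scatter. Compound 3 `ClCc1cccc(Cn2cnc3nc(Cl)nc(Cl)c32)c1` has not yet been measured. It differs from compound 1 by one change: chloro in place of hydrogen on an aromatic carbon. Going by the values given here, no single-change step has been measured, so the size of this step is open. Since compound 2, which carries the same two chloro groups on the core, sits at 1410 nM, a modest move toward a lower number is expected for compound 3, with a step of a 1.9-fold lower number from compound 1 to compound 3 (0.27 log units; within the scatter). Compound 3 is therefore estimated at 1800 nM, within a range of 800 nM to 4000 nM.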

Compound 3, concentration for 50% growth inhibition: 17000 nM
The estimate for compound 3 lay 9.4-fold (0.98 log units) below the measured number; the measured number lies above the stated range.
By their numbers in this assay, from the lowest: compound 2; then compound 1; then compound 3.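

Going by these compounds alone, this is the first step that isolates one change: in this assay chloro in place of hydrogen on the aromatic carbon between two ring nitrogen atoms gives a 5.0-fold higher number from compound 1 to compound 3 (0.70 log units; beyond the scatter) and thus weaker inhibition of growth. On the core of compound 1, then, this position is not indifferent to substitution, and adding this single chlorine atom there lowers growth inhibition instead of raising it. Nothing measured here accounts for this loss.

On these data alone, what an amine, a methoxy group or a fluoro on this same carbon would do remains open, so the result cannot yet be assigned to chloro alone or to any added group at this position. Also open, as far as these compounds go, is whether the step would keep its size if the chloromethyl group gave way to a longer chain.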